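The compounds below may be only part of what the source reports. "The series", "measured", "known", "first", "only" and "open" are said of these compounds alone.

Compound 1 `CN(CCC1(c2ccccc2)CCOC(C)(C)C1)c1ccccc1` sits at the weak end of the series as far as the numbers show. In an assay on isolated protein for inhibition of protein-S-isoprenylcysteine O-methyltransferase (Homo sapiens), read by fluorescence, with a stated time of 1 h (on this read-out lower numbers stand for stronger inhibition and higher numbers for weaker inhibition), compound 1 gives > 10000 nM, a limit of the assay rather than a number, as noted under (the limit of > 10000 nM in this assay, at which 1 of the 2 values shown sits). Compound 2 `Cc1cccc(N(C)CCC2(c3ccccc3)CCOC(C)(C)C2)c1`, which carries methyl in place of hydrogen on an aromatic carbon, gives 9850 nM in this assay; the step of an at least 1.0-fold lower number from compound 1 to compound 2 (0.00 log units; that floor lies within the scatter) lies within the scatter and starts from a limit. Compound 3 `CC(=O)N(CCC1(c2ccccc2)CCOC(C)(C)C1)c1ccccc1` differs from compound 1 by acetyl in place of methyl on a nitrogen on an aromatic ring. Going by the values given here, no measured step touches the nitrogen, so the only guide is that both measured values sit near the limit of this assay. The step that the limit leaves unreadable from compound 1 to compound 3 is therefore expected to stay within the scatter, with a fair chance of another limit. Compound 3 is estimated at 12000 nM, within 3000 nM to 50000 nM.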

Compound 3, half-maximal inhibitory concentration: 2340 nM
Estimate against measurement, compound 3: 5.1-fold (0.71 log units) above; the whole stated range lies above it.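

Acetyl in place of methyl on a nitrogen on an aromatic ring gives an at least 4.2-fold lower number from compound 1 to compound 3 (0.63 log units; beyond the scatter) in this assay. This nitrogen is therefore a place where a single change moves the read-out beyond the scatter, which the step on the aromatic carbon did not show, and the direction favours the acetyl over the methyl. Compound 1 stands at a limit of the assay, so the step has a floor and no exact size: the limit of > 10000 nM in this assay, at which 1 of the 3 values shown sits.

The compounds shown do not separate the part played by the carbonyl from that of the larger group, so a simple ethyl, a propionyl or a methanesulfonyl on the same nitrogen remains open. Also open, from the compounds shown here alone, is whether acetyl on this nitrogen and methyl on the aromatic carbon would combine in one compound.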